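The source may hold more compounds than are shown below. What is called first, only, known or untested is meant among the compounds shown, and "the series" means these compounds.

Measured compounds:
Compound 1, `Cn1c(/C=C2/C(=O)Nc3ccc([N+](=O)[O-])cc32)nc2ccccc21`. In a functional assay on PC-3 cells (Homo sapiens) for cytotoxicity, read by MTT assay, with a stated time of 48 h (a lower number here means a stronger inhibitor, a higher number a weaker inhibitor), compound 1 gives > 50000 nM, which is a limit of the assay rather than a number.
Compound 2, `Cn1c(/C=C2/C(=O)Nc3ccc(Cl)cc32)nc2ccccc21`. In this assay compound 2 gives > 50000 nM, also a limit.
Compound 3, `CCn1c(/C=C2/C(=O)Nc3ccc(Cl)cc32)nc2ccccc21`. In this assay compound 3 gives > 50000 nM, again a limit.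

Compound 4, `CCn1c(/C=C2/C(=O)Nc3ccc([N+](=O)[O-])cc32)nc2ccccc21`, is not yet measured. It differs from compound 3 by nitro in place of chloro on an aromatic carbon. The same change, (nitro in place of chloro on an aromatic carbon), links compound 2 to compound 1, where it gave a step that the two limits leave unreadable from compound 2 to compound 1. The cores of compound 3 and compound 2 differ by methyl in place of hydrogen on a saturated chain carbon bound to an aromatic nitrogen, a step that the two limits leave unreadable from compound 2 to compound 3. Since every value sits at the limit of > 50000 nM in this assay, at which 3 of the 3 values shown sit, no step size can be read, and compound 4 is expected to behave alike. The step from compound 3 to compound 4 is estimated at a step that the limit leaves unreadable from compound 3 to compound 4. Compound 4 is expected to give about 80000 nM, plausibly between 30000 nM and 300000 nM, most likely reported again only as a limit.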

Compound 4, half-maximal inhibitory concentration: 40100 nM
Compound 4: middle estimate off by 2.0-fold (0.30 log units), on the high side; low and high end bracket the measured number.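

In this assay, nitro in place of chloro on an aromatic carbon gives an at least 1.2-fold lower number from compound 3 to compound 4 (0.09 log units; that floor lies within the scatter), and methyl in place of hydrogen on the saturated chain carbon gives an at least 1.2-fold lower number from compound 1 to compound 4 (0.09 log units; that floor lies within the scatter); compound 4 thus returns a number, but neither step is shown to exceed ordinary scatter. The same nitro-for-chloro change on the other core, and the remaining steps among compounds 1, 2 and 3, cannot be read, so nothing shows whether the change carries the same size from one core to the other. The true step sizes stay hidden because most values are limits: the limit of > 50000 nM in this assay, at which 3 of the 4 values shown sit.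

The compounds shown leave open whether an amine or a carboxylic acid in place of the chloro, or a longer chain on the aromatic nitrogen, would give a step clearly beyond the scatter.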